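This account rests on a few compounds, and the source may have more. Where it says the series, first, only, none or still open, it means among the compounds named here.

Of the compounds shown here, two have so far been measured in an assay on HEK293 cells for agonist activity at Toll-like receptor 8 (Homo sapiens), read by reporter gene assay; on this read-out higher numbers stand for an effect only at larger amounts of compound and lower numbers for an effect already at smaller amounts. Compound 1 `CCCCOC(=O)n1c(N)nc2ccccc21` is recorded in this assay as "not active" (no number reported), so no number stands for it. In this assay compound 2 `CCCCCn1c(N)nc2c(OC)cccc21` gives 3740 nM. Among the measured compounds shown here, compound 2 is therefore the only compound with a number, and the only one against which an unmeasured compound can be weighed.

Compound 3 `CCCCCn1c(N)nc2c(N(C)C)cccc21` has not yet been measured in this assay. It differs from compound 2 in one place: dimethylamino in place of methoxy on an aromatic carbon. For the measured compounds named here, no step between two measured compounds shows how an exchange of this kind plays out, so the measured data set no direction. Both groups are small and both bring no hydrogen-bond donor and one hydrogen-bond acceptor, so the step from compound 2 to compound 3 is expected to be modest, a 1.2-fold lower number from compound 2 to compound 3 (0.10 log units; within the scatter), with no firm direction and possibly not beyond the scatter. Compound 3 is accordingly expected to give about 3000 nM in this assay, within a range from 800 nM to 12000 nM. Whether the measurement bears this out is the next question.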

Compound 3, half-maximal effective concentration: 7120 nM
The estimate for compound 3 lay 2.4-fold (0.38 log units) below the measured number, within the range that was stated.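

Dimethylamino in place of methoxy on this aromatic carbon of the six-membered aromatic ring gives a 1.9-fold higher number from compound 2 to compound 3 (0.28 log units; within the scatter) in this assay, and this is the first step that can be read at this position. The earlier compounds shown here could not show this, since compound 1 has no number and compound 2 alone set no direction; now the two groups can be said to give values that lie within the usual scatter of each other, so this exchange shows no real change on this read-out, and the position keeps a measurable effect with either group. Nothing measured here bears on what lies behind this outcome.

Going by these compounds, whether a primary amine, a hydroxyl or a carboxylic acid on the same aromatic carbon would move the number beyond the scatter remains open, as does the effect of an ethoxy group or a longer chain there. Compound 1 differs from compound 2 in more than one place, so what separates a compound without a number from one with a number also stays unresolved.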